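The compounds below may be only part of what the source reports. "The series", "measured", "known", "first", "only" and "open" are said of these compounds alone.

In a functional assay on HL-60 cells (Homo sapiens) for cytotoxicity, read by WST assay, with a stated time of 48 h (a higher number here means a weaker inhibitor, a lower number a stronger inhibitor), compound 1 (`COc1cc(C(c2ccc(O)c(OC)c2)[C@@H](C)[C@@H](C)CF)ccc1O`) gives 38000 nM and compound 2 (`COC[C@H](C)[C@@H](C)C(c1ccc(O)c(OC)c1)c1ccc(O)c(OC)c1`) gives 68000 nM, so compound 2 stands level with compound 1 within the scatter. Compound 3 (`COc1cc(C(c2ccc(O)c(OC)c2)[C@@H](C)[C@H](C)CO)ccc1O`) differs from compound 2 in one place: 2-(hydroxymethyl)-1-methylpropyl in place of 2-(methoxymethyl)-1-methylpropyl on a saturated chain carbon bound to two aromatic carbons. Among the compounds with values here, only one measured step alters this same substituent, a 1.8-fold higher number from compound 1 to compound 2 (0.25 log units; within the scatter), and no measured step shows a change beyond the scatter. No shift beyond the scatter is therefore expected in this assay, and the estimated step is a 1.4-fold lower number from compound 2 to compound 3 (0.13 log units; within the scatter). For compound 3 the expected value is 50000 nM, with an estimated range of 20000 nM to 100000 nM.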

Compound 3, half-maximal inhibitory concentration: > 100000 nM
Compound 3: only a limit was reported (the forecaster's own chance of this, stated with the estimate: 15%); at least 2.0-fold (0.30 log units) between middle value and limit.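

In this assay compound 3 reaches only a limit of the assay, not a number: the limit of > 100000 nM in this assay, at which 1 of the 3 values shown sits.

Even so, the change from 2-(fluoromethyl)-1-methylpropyl to 2-(hydroxymethyl)-1-methylpropyl gives the first step at this position to pass the scatter, an at least 2.6-fold higher number from compound 1 to compound 3 (0.42 log units; beyond the scatter). Against the methoxymethyl compound, the step is only a floor, an at least 1.4-fold higher number from compound 2 to compound 3 (0.16 log units; that floor lies within the scatter), so that pair cannot yet be ordered.

As far as these compounds go, how far compound 3 lies past its limit remains open. So does the effect of an aminomethyl group, a carboxylic acid or a longer chain at this place.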